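The source may report more compounds than this note shows. Statements on the series, on what has been measured and on what is new or still open speak of the compounds shown alone.

Among the compounds with values here, compound 2 `COc1cc2c(Oc3ccc(NC(=O)c4cc(-c5cccc(Cl)c5)nc5ccccc45)cc3F)ccnc2cc1OCCCN1CCC(C)CC1` gives the lower of the two numbers so far: in a functional assay on SMMC-7721 cells (Homo sapiens) for cytotoxicity, read by MTT assay, with a stated time of 72 h (on this read-out lower numbers stand for stronger inhibition and higher numbers for weaker inhibition), compound 2 gives 80 nM. Compound 1 `COc1cc2c(Oc3ccc(NC(=O)c4cc(-c5ccccc5)nc5ccccc45)cc3F)ccnc2cc1OCCCN1CCCCC1` differs from compound 2 in two places at once; in this assay compound 1 gives a higher number, 290 nM, a gap beyond the usual scatter. Compound 3 `COc1cc2c(Oc3ccc(NC(=O)c4cc(-c5ccccc5)nc5ccccc45)cc3F)ccnc2cc1OCCCN1CCC(C)CC1` is made from compound 2 by hydrogen in place of chloro on an aromatic carbon. Since compound 2 and compound 1 differ in two places, no single change has been measured on its own, so this step is expected to be modest, toward a weaker result. The expected step from compound 2 to compound 3 is a 1.9-fold higher number from compound 2 to compound 3 (0.27 log units; within the scatter). Compound 3 is therefore estimated at 150 nM, within a range from 60 nM to 400 nM.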

Compound 3, half-maximal inhibitory concentration: 160 nM
Beside the measured number, compound 3's estimate is 1.1-fold (0.03 log units) below it; the range from low to high includes it.
By their numbers in this assay, from the lowest: compounds 2, 3 and 1 (each within the scatter of the next, the first and the last beyond it).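

In this assay, chloro can now be read on its own at this aromatic carbon: hydrogen in its place gives a 2.0-fold higher number from compound 2 to compound 3 (0.30 log units; within the scatter), and methyl in place of hydrogen on the saturated ring carbon gives a 1.8-fold lower number from compound 1 to compound 3 (0.26 log units; within the scatter). Each single change therefore stays within the scatter, although the two together span a gap beyond it. No outside measurement bears on these numbers. The compounds shown leave open whether another group on this aromatic carbon, such as methoxy or fluoro, would shift the number beyond the scatter.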